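The source may hold more compounds than are shown below. What is called first, only, known or untested is meant among the compounds shown, and "the series" means these compounds.

Measured so far in a functional assay on A-375 cells (Homo sapiens) for cytotoxicity, read by MTT assay, with a stated time of 48 h; a higher number here means a weaker inhibitor, a lower number a stronger inhibitor:
compound 1 `CC1(C)S[C@@H]2/C(=C\C(=O)c3cc(C(F)(F)F)cc(C(F)(F)F)c3)C(=O)N2[C@H]1C(=O)OC(c1ccccc1)c1ccccc1` gives 39200 nM
compound 2 `CC1(C)S[C@@H]2/C(=C\C(=O)c3cc(F)cc(F)c3)C(=O)N2[C@H]1C(=O)OC(c1ccccc1)c1ccccc1` gives 19100 nM
compound 3 `CC1(C)S[C@@H]2C/C(=C\C(=O)c3ccccc3)C(=O)N2[C@H]1C(=O)OC(c1ccccc1)c1ccccc1` gives > 100000 nM, which is a limit of the assay and not a number.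

Compound 2 stands lowest of the two numbers shown in this assay. Compound 1 gives the nearer value, a higher number that sits beyond the usual scatter, so compound 2 reads as the stronger of those two. Compound 3 sits at the limit (the limit of > 100000 nM in this assay, at which 1 of the 3 values shown sits), and nothing more than that can be read from it.

Compound 4 `CCOC(=O)/C=C1/C(=O)N2[C@@H]1SC(C)(C)[C@@H]2C(=O)OC(c1ccccc1)c1ccccc1` has not yet been measured in this assay. It differs from compound 2 in one place: ethoxy in place of 3,5-difluorophenyl on a carbonyl carbon. Cut one bond further out, the change reads as (3,5-difluorophenyl)carbonyl to ethoxycarbonyl. For the measured compounds named here, both measured numbers come from compounds carrying an aryl carbonyl on the exocyclic chain, and no measured step in this assay tells how the series responds to losing that aromatic ring. With so little to go on, the expectation for compound 4 is a step toward a higher number, of moderate size, though a step within the scatter cannot be ruled out. The expected step from compound 2 to compound 4 is a 2.6-fold higher number from compound 2 to compound 4 (0.42 log units; beyond the scatter). For compound 4 the estimated value in this assay is 50000 nM, expected to fall between 15000 nM and 150000 nM.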

Compound 4, half-maximal inhibitory concentration: 7000 nM
The estimate for compound 4 lay 7.1-fold (0.85 log units) above the measured number; the measured number lies below the stated range.
By their numbers in this assay, from the lowest: compound 4; then compound 2; then compound 1. At a limit, above all of these: compound 3.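

In this assay, the aromatic ring on this carbonyl carbon is not required for activity: ethoxy in place of 3,5-difluorophenyl gives a 2.7-fold lower number from compound 2 to compound 4 (0.44 log units; beyond the scatter), a modest step that lies beyond the scatter. For the compounds shown here, compound 1, compound 2 and compound 3 all carry an aryl carbonyl on the exocyclic chain, whereas compound 4 gives the first reading at this position with ethoxycarbonyl, which has no ring, fewer heavy atoms and one hydrogen-bond acceptor entering with the ethoxy. The data shown do not establish whether the step follows from losing the 3,5-difluorophenyl or from gaining the ethoxy.

Still open, on these data alone, is which part of the ethoxy carries the step: a methoxy, a longer alkoxy chain, a carboxylic acid or an amine-derived amide at the same carbonyl carbon would separate the role of the oxygen from that of the alkyl part. Also open, as far as these compounds go, is whether the order of compound 2 and compound 4 holds beyond this single cell line, as all the values shown come from one assay.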